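The source may hold more compounds than are shown below. What is called first, only, known or untested is meant among the compounds shown, and "the series" means these compounds.

Measured so far in an ADME assay on microsomes from liver (Homo sapiens) for metabolic stability, read by LC-MS, with a stated time of 30 min, tested at 0.1 uM; on this read-out lower numbers stand for a less stable compound and higher numbers for a more stable compound:
- compound 1 `FC(F)(F)c1cccc(-c2nc3cnc(Nc4ccccn4)cc3[nH]2)c1`: 69%
- compound 2 `COc1ccnc(Nc2cc3[nH]c(-c4cccc(C(F)(F)F)c4)nc3cn2)c1`: 80%

Compound 2 has the higher of the two numbers; the step of a number 11 percentage points higher from compound 1 to compound 2 (beyond the scatter) lies beyond the scatter and corresponds to methoxy in place of hydrogen on an aromatic carbon.

Compound 3 `FC(F)(F)c1cccc(-c2nc3cnc(Nc4cccnn4)cc3[nH]2)c1` is not yet measured. The change from compound 2 is pyridazin-3-yl in place of 4-methoxypyridin-2-yl on a nitrogen on an aromatic ring. Within the data shown here, only one measured step bears on this: the methoxy step from compound 1 to compound 2, which compound 3 undoes, since compound 3 carries no methoxy. Among the measured compounds shown here, no measured pair shows the exchange of the ring itself, so that part of the change is uncovered. The expected step in this assay is therefore a fall of about a number 10 percentage points lower from compound 2 to compound 3 (within the scatter), back towards compound 1, with a wide range. Compound 3 is estimated at 70% (range 52% to 86%).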

Compound 3, percent of the compound remaining: 84%
Beside the measured number, compound 3's estimate is 14 percentage points below it; measured number inside the range.
By their numbers in this assay, from the lowest: compound 1; then compounds 2 and 3 (each within the scatter of the next).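

In this assay, the ring on this nitrogen can be changed without a methoxy group and the number still rises: pyridazin-3-yl in place of pyridin-2-yl gives a number 15 percentage points higher from compound 1 to compound 3 (beyond the scatter). Among these compounds, the methoxy group is therefore not the only change at this position that lifts the number above that of compound 1, and pyridazin-3-yl in place of 4-methoxypyridin-2-yl gives a number 4 percentage points higher from compound 2 to compound 3 (within the scatter), so the two groups cannot be told apart here. No available measurement accounts for either step.

On these data alone, it remains open whether a methoxy group on the ring with 2 hetero atoms would add to the step seen for that ring alone. Also open, as far as these compounds go, is how a dimethylamino group or a carboxylic acid on this ring would read in this assay.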